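Does a hydroxy group help on a second indolinone core?

This account rests on a few compounds, and the source may have more. Where it says the series, first, only, none or still open, it means among the compounds named here.

In a functional assay on cells (Cancer cell lines, Homo sapiens) for inhibition, with a stated time of 48 h (on this read-out lower numbers stand for stronger inhibition of growth and higher numbers for weaker inhibition of growth), the three measured compounds gave these numbers:

compound 1 `COc1cc2c(/C=C3/C(=O)N(C)c4ccccc43)c(Cl)n(C)c2cc1C` — 280 nM
compound 2 `COc1cc2c(/C=C3/C(=O)N(C)c4ccc(O)cc43)c(Cl)n(C)c2cc1C` — 60 nM
compound 3 `COc1cc2c(/C=C3/C(=O)N(C)c4ccccc43)c[nH]c2cc1C` — 1780 nM

Compound 1 and compound 2 share one core and differ only by hydroxy in place of hydrogen on an aromatic carbon. That change gave a 4.7-fold lower number from compound 1 to compound 2 (0.67 log units; beyond the scatter), so in this assay compound 2 gives the lower number of the pair.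

Compound 3 carries a different core; the difference between the two cores is not broken down here. Of the three measured compounds, compound 3 gives the highest number in this assay.

Compound 4 `COc1cc2c(/C=C3/C(=O)N(C)c4ccc(O)cc43)c[nH]c2cc1C` is built on the core of compound 3 and differs from it by hydroxy in place of hydrogen on an aromatic carbon. Within the data shown here, both place descriptions read word for word alike, so this is the same change as the one from compound 1 to compound 2, now made on the second core.

Among the measured compounds shown here, for compound 4 an estimate of a 4.7-fold lower number from compound 3 to compound 4 (0.67 log units; beyond the scatter) in this assay is expected, resting on the one earlier example of the change, a 4.7-fold lower number from compound 1 to compound 2 (0.67 log units; beyond the scatter), applied to the number of compound 3. Compound 4 is therefore estimated at 380 nM, with a likely range from 150 nM to 950 nM.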

Compound 4, concentration for 50% growth inhibition: 2750 nM
For compound 4 the middle estimate is 7.2-fold (0.86 log units) below the measured one, and the stated range ends below it.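

On the core of compound 3, hydroxy in place of hydrogen gave a 1.5-fold higher number from compound 3 to compound 4 (0.19 log units; within the scatter) in this assay, so on this core the change has no effect that can be told apart from the usual variation between repeated measurements. Set side by side, the two cores do not respond to the change in the same way: the same change on two cores in this assay, a 4.7-fold lower number (0.67 log units; beyond the scatter) from compound 1 to compound 2 and a 1.5-fold higher number (0.19 log units; within the scatter) from compound 3 to compound 4, 7.2-fold (0.86 log units) apart, beyond the scatter of two such steps. Among these compounds, this shows that the gain seen on the core of compound 1 cannot be assumed on the core of compound 3, but with only one pair of compounds on each core, it does not show which difference between the cores matters or how the change would behave on any other core.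

The compounds shown leave open whether another group in the same place, such as an amine or a carboxylic acid, would respond differently on the two cores. They also leave open whether hydroxy elsewhere on the same ring would follow either result.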